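A few compounds are considered here, and "the series" means these few. Any claim that something is new, unique, unknown or untested is made for them only; others in the source may bear on it.

Among the measured compounds shown here, compound 2 `CCCCNc1nc(N)nc2c1CN(Cc1ccco1)CC2` holds the lowest of the two numbers measured so far in an assay on HEK293 cells for agonist activity at Toll-like receptor 8 (Homo sapiens), read by a luciferase reporter, with a stated time of 6 h; on this read-out lower numbers stand for an effect already at smaller amounts and higher numbers for an effect only at larger amounts of compound: compound 2 gives 0.08 uM, whereas compound 1 `CCCCNc1nc(N)nc2c1CN(C(=O)c1ccccc1)CC2` gives 1.4 uM. For the measured compounds named here, the single measured step, an 18-fold lower number from compound 1 to compound 2 (1.24 log units; beyond the scatter), accompanied the exchange of benzoyl for (furan-2-yl)methyl on the amine nitrogen in the ring. Compound 3 `CCCCNc1nc(N)nc2c1CN(C(=O)C1CCC1)CC2` has not yet been measured; it differs from compound 2 by cyclobutylcarbonyl in place of (furan-2-yl)methyl on an amine nitrogen in a ring. Going by the values given here, this change brings a carbonyl back onto that nitrogen, so the step of an 18-fold lower number from compound 1 to compound 2 (1.24 log units; beyond the scatter) bears on it in reverse, and the only guidance is that compound 1 gives 1.4 uM with benzoyl in the same place. A sizable rise in the number is therefore expected for compound 3, with a 15-fold higher number from compound 2 to compound 3 (1.18 log units; beyond the scatter) as the estimated step. Compound 3 is estimated at 1.2 uM in this assay, within a range from 0.25 uM to 6 uM.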

Compound 3, minimum effective concentration: 0.4 uM
Compound 3: middle estimate off by 3.0-fold (0.48 log units), on the high side, and the stated range covers the measured number.
By their numbers in this assay, from the lowest: compound 2; then compound 3; then compound 1.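

In this assay, a carbonyl on the amine nitrogen in the ring does not alone fix the number: with the carbonyl kept, cyclobutyl in place of phenyl gives a 3.5-fold lower number from compound 1 to compound 3 (0.54 log units; beyond the scatter), so the group on the carbonyl carbon also matters. Even so, the cyclobutylcarbonyl group does not match (furan-2-yl)methyl at this position, as the exchange gives a 5.0-fold higher number from compound 2 to compound 3 (0.70 log units; beyond the scatter), which leaves compound 2 with the lowest number of the three. No measurement is at hand that would explain either step.

The compounds shown do not separate the carbonyl from the ring carried on it, and a cyclobutylmethyl or benzyl group on the same nitrogen would address that. Going by these compounds, how a longer chain, such as pentanoyl, would compare also remains open.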